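The source may hold more compounds than are shown below. What is called first, only, known or untested is meant among the compounds shown, and "the series" means these compounds.

Of the compounds shown here, two have been measured in an assay on isolated protein for agonist activity at Bile acid receptor (Homo sapiens), read by AlphaScreen, with a stated time of 30 min; a higher number here means that more compound is needed for the effect, a lower number that less compound is needed. Compound 1 `Cc1nn(-c2ccccc2Cl)c2c1C(c1ccc(Oc3ccccc3)cc1)SC(C)C(=O)N2` gives 2700 nM, and compound 2 `COc1ccc(Oc2ccc([C@H]3S[C@@H](C)C(=O)Nc4c3c(C)nn4-c3ccccc3C)cc2)cc1` gives 2200 nM; these two numbers lie within the usual scatter of each other, so neither compound stands apart. Compound 3 `COc1cccc(Oc2ccc([C@H]3S[C@@H](C)C(=O)Nc4c3c(C)nn4-c3ccccc3C)cc2)c1` is the next candidate; it holds the same atoms as compound 2, joined differently: 3-methoxyphenyl in place of 4-methoxyphenyl on an oxygen on an aromatic ring. Going by the values given here, no measured pair shows what such a change does here, so the step of a 1.1-fold higher number from compound 2 to compound 3 (0.06 log units; within the scatter) is expected to be small, with no direction beyond the scatter. Compound 3 is therefore estimated at 2500 nM, within a range from 900 nM to 7000 nM.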

Compound 3, half-maximal effective concentration: 1700 nM
Compound 3: the middle estimate sits 1.5-fold (0.17 log units) above what was measured; the range from low to high includes it.
By their numbers in this assay, from the lowest: compounds 3, 2 and 1 (each within the scatter of the next).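

Placing 3-methoxyphenyl in place of 4-methoxyphenyl on an oxygen on an aromatic ring gives a 1.3-fold lower number from compound 2 to compound 3 (0.11 log units; within the scatter) in this assay, so this is the first direct reading at this position. Within that scatter, the two methoxyphenyl groups cannot be told apart, and the change shows no direction. No outside measurement bears on this result.

The compounds shown leave open whether the methoxy group itself matters here. An amine, a carboxylic acid or a longer chain in its place might move the number beyond the scatter, or might not.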